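The source may report more compounds than this note shows. Statements on the series, on what has been measured and on what is new or still open speak of the compounds shown alone.

Measured in a functional assay on A549 cells (Homo sapiens) for antiproliferative activity, read by MTT assay, with a stated time of 48 h; a higher number here means a weaker inhibitor, a lower number a stronger inhibitor:
- Compound 1 `C/C(=C\CC/C(C)=C/CC[C@@H]1[C@@]2(C)CCC(=O)C(C)(C)[C@H]2CC[C@@]1(C)O)CC/C=C(\C)C(=O)OCc1cn(-c2ccc(F)cc2)nn1`: > 150000 nM, a limit
- Compound 2 `C/C(=C\CC/C(C)=C/CC[C@@H]1[C@@]2(C)CCC(=O)C(C)(C)[C@H]2CC[C@@]1(C)O)CC/C=C(\C)C(=O)OCc1cn(-c2ccc(Br)cc2)nn1`: > 150000 nM, a limit

Compound 2 stands only at a limit, with no number to work from, and the same holds for the other measured compound: the limit of > 150000 nM in this assay, at which 2 of the 2 values shown sit. Compound 3 `C/C(=C\CC/C(C)=C/CC[C@@H]1[C@@]2(C)CCC(=O)C(C)(C)[C@H]2CC[C@@]1(C)O)CC/C=C(\C)C(=O)OCc1cn(-c2cccc(F)c2)nn1` has 3-fluorophenyl in place of 4-bromophenyl on an aromatic nitrogen. Within the data shown here, the one measured step that bears on this is a step that the two limits leave unreadable from compound 1 to compound 2. No change beyond the scatter is therefore expected in this assay, and another limit is the likely report. The expected step is a step that the limit leaves unreadable from compound 2 to compound 3. For compound 3 the estimated value is 180000 nM, with an expected range of 90000 nM to 350000 nM.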

Compound 3, half-maximal inhibitory concentration: 124000 nM
For compound 3 the middle estimate is 1.5-fold (0.16 log units) above the measured one, within the range that was stated.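

In this assay, among these compounds, compound 3 gives 124000 nM, the first number that is not a limit. This places 3-fluorophenyl on the aromatic nitrogen at an at least 1.2-fold lower number from compound 2 to compound 3 (0.08 log units; that floor lies within the scatter) and at an at least 1.2-fold lower number from compound 1 to compound 3 (0.08 log units; that floor lies within the scatter). The second step keeps the fluorine and changes only 4-fluorophenyl to 3-fluorophenyl, yet both floors lie within the scatter, so neither shows a real gain.

As far as these compounds go, the true size of these steps remains open, and the step between the two limits cannot be read. Also open, from the compounds shown here alone, is whether an amine or a carboxylic acid on the phenyl ring would give a change beyond the scatter.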